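Swapping butylamino for phenyl in compound 2

The source may hold more compounds than are shown below. What is called first, only, known or untested is meant among the compounds shown, and "the series" means these compounds.

Among the measured compounds shown here, in an ADME assay on LL24 cells (Homo sapiens) for inhibition, read by MTT assay, with a stated time of 24 h (on this read-out lower numbers stand for stronger inhibition and higher numbers for weaker inhibition), compound 2 (`CCCCNc1ccc(C(=O)N/N=C/c2ccc([N+](=O)[O-])o2)cc1`) gives 47000 nM, the only actual number so far. Compound 1 (`CCCCOc1ccc(C(=O)N/N=C/c2ccc([N+](=O)[O-])o2)cc1`) gives only a limit, > 200000 nM. For the measured compounds named here, the one measured step, an at least 4.2-fold lower number from compound 1 to compound 2 (0.62 log units; beyond the scatter), is beyond the scatter and brought butylamino in. Compound 3 (`O=C(N/N=C/c1ccc([N+](=O)[O-])o1)c1ccc(-c2ccccc2)cc1`) has phenyl in place of butylamino on an aromatic carbon. Going by the values given here, no measured step covers phenyl, so the step of an at least 4.2-fold lower number from compound 1 to compound 2 (0.62 log units; beyond the scatter) is only an indirect guide, and a modest move toward weaker inhibition is expected. The expected step is a 1.7-fold higher number from compound 2 to compound 3 (0.23 log units; within the scatter). Compound 3 is estimated at 80000 nM, with an expected range of 20000 nM to 200000 nM.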

Compound 3, half-maximal inhibitory concentration: > 200000 nM
Compound 3 ended at the assay's limit; the forecaster's own chance of this, stated with the estimate: 35%; middle value at least 2.5-fold (0.39 log units) away from the limit.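

In this assay, the group on this aromatic carbon, para to a large group, clearly matters: phenyl in place of butylamino gives an at least 4.2-fold higher number from compound 2 to compound 3 (0.62 log units; beyond the scatter), reversing the gain seen with butylamino. Of the three groups shown, only butylamino gives an actual number, and the step between compound 1 and compound 3 cannot be read because both values are limits: the limit of > 200000 nM in this assay, at which 2 of the 3 values shown sit.

On these data alone, how butoxy and phenyl rank against each other stays open. So does whether a longer chain such as hexylamino, or a dimethylamino group, on this carbon would give a lower number than butylamino.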